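The compounds below may be only part of what the source reports. "The series", "measured", "known", "first", "only" and "open" are said of these compounds alone.

Series notes. Compound 1 `C/C=C/C(=O)Nc1cccc(Oc2nc(Nc3cccc(OC)c3)nc3ccsc23)c1` gives 46000 nM in an ADME assay on L02 cells (Homo sapiens) for inhibition, read by MTT assay, with a stated time of 72 h; a higher number here means a weaker inhibitor, a lower number a stronger inhibitor. Compound 2 `COc1cccc(Nc2nc(Oc3cccc(NC(=O)C=C(C)C)c3)c3sccc3n2)c1` carries a branched alkenyl group on the carbonyl; in this assay compound 2 gives "not determined" (no result reported), so no single number anchors it. Compound 3 `CCC/C=C/C(=O)Nc1cccc(Oc2nc(Nc3cccc(OC)c3)nc3ccsc23)c1` differs from compound 2 by pent-1-en-1-yl in place of 2-methylprop-1-en-1-yl on a carbonyl carbon. Within the data shown here, no step between measured compounds is available for this change, so no shift beyond the scatter is expected in this assay in either direction, given that compound 1 with its unbranched alkenyl chain on the carbonyl sits at 46000 nM. Compound 3 is therefore expected to give 40000 nM in this assay, within a range from 15000 nM to 110000 nM.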

Compound 3, half-maximal inhibitory concentration: > 50000 nM
Compound 3: no number, only a limit; the forecaster's own chance of this, stated with the estimate: 20%; middle value at least 1.2-fold (0.09 log units) from the limit.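

In this assay compound 3 gives > 50000 nM, which is a limit and not a number. Ethyl on the unbranched chain gives an at least 1.0-fold higher number from compound 1 to compound 3 (0.03 log units; that floor lies within the scatter), so the pent-1-en-1-yl group on the carbonyl shows no move towards a stronger inhibitor at this position. The true size of the step stays unreadable because the reading ends at a limit: the limit of > 50000 nM in this assay, at which 1 of the 3 values shown sits.

The step from compound 2 to compound 3 cannot be read, so branched and unbranched alkenyl groups remain uncompared. Going by these compounds, whether an amine in place of the ethyl would lower the number also remains open.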